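From isopropylcarbamoyl to fluoro on a weak growth inhibitor

The source may report more compounds than this note shows. Statements on the series, on what has been measured and on what is new or still open speak of the compounds shown alone.

Three compounds have been measured so far in a functional assay on MCF7 cells (Homo sapiens) for antiproliferative activity, read by CCK-8 assay, with a stated time of 72 h (a lower number here means a stronger inhibitor of growth, a higher number a weaker inhibitor of growth), as follows:

Compound 1 `CCC1C(=O)N(C)c2cnc(Nc3ccc(S(=O)(=O)NC)cc3)nc2N1c1ccn(C)n1` gives 3750 nM
Compound 2 `CCC1C(=O)N(C)c2cnc(-n3ccc4cc(C(=O)NC(C)C)ccc43)nc2N1c1ccn(C)n1` gives 8420 nM
Compound 3 `CCCCNS(=O)(=O)c1ccc(Nc2ncc3c(n2)N(C2CCCC2)[C@H](CC)C(=O)N3C)cc1` gives 459 nM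

Compound 2 has the highest number of the three, which makes it the weakest inhibitor of growth here. Compound 1 lies nearest to it and compound 3 furthest, and both gaps go beyond the usual scatter.

Compound 4 `CCC1C(=O)N(C)c2cnc(-n3ccc4cc(F)ccc43)nc2N1c1ccn(C)n1` has not yet been measured. It differs from compound 2 in one place fluoro in place of isopropylcarbamoyl on an aromatic carbon with fluoro in place of isopropylcarbamoyl on an aromatic carbon. Going by the values given here, no two measured compounds differ in just one place, so the data do not show what such a change does in this assay and the direction stays open. The starting point is therefore compound 2 at 8420 nM as the best guide. The expected outcome is an estimated 1.2-fold lower number from compound 2 to compound 4 (0.08 log units; within the scatter) that stays within the scatter. For compound 4 the estimated value is 7000 nM (2500 nM to 20000 nM).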

Compound 4, concentration for 50% growth inhibition: 24700 nM
For compound 4 the middle estimate is 3.5-fold (0.55 log units) below the measured one; the whole stated range lies below it.
By their numbers in this assay, from the lowest: compound 3; then compound 1; then compound 2; then compound 4.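

In this assay, fluoro in place of isopropylcarbamoyl on this aromatic carbon gives a 2.9-fold higher number from compound 2 to compound 4 (0.47 log units; beyond the scatter) and so a weaker inhibitor of growth. This first single-place comparison in the set shows that the position is not indifferent to what it carries, and that the larger group of the two goes with the stronger inhibition here. The change takes away 6 heavy atoms, a hydrogen-bond donor and a hydrogen-bond acceptor all at once, and nothing measured here explains why the number rises.

From the compounds shown here alone, one step cannot separate size from the donor or the acceptor, so it remains open which of these matters. Going by these compounds, an amine, a carboxylic acid or a longer chain on the amide at this place could help to tell them apart, and whether the same change behaves alike on other parts of the series also stays unknown.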